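Swapping Propyl for Bromophenyl: Expected Toxicity of Compound 4

The source may report more compounds than this note shows. Statements on the series, on what has been measured and on what is new or still open speak of the compounds shown alone.

Measured compounds:
compound 1, `COc1ccc(-c2cnc(NC(=O)c3ccc([N+](=O)[O-])cc3)n2C)cc1`: in a toxicity assay on THP-1 cells (Homo sapiens) for inhibition (on this read-out lower numbers stand for higher toxicity in this test and higher numbers for lower toxicity in this test), compound 1 gives > 100000 nM, a limit of the test rather than a number.
compound 2, `COc1ccc(C(=O)Nc2ncc(-c3ccc(OC)cc3)n2C)cc1`: compound 2 gives > 100000 nM, again a limit.
compound 3, `CCCC(=O)Nc1ncc(-c2ccc(OC)cc2)n1C`: compound 3 gives > 100000 nM, also a limit.

Compound 3 therefore stands where every measured compound stands: at the limit, with no number of its own. The two measured steps, a step that the two limits leave unreadable from compound 1 to compound 2 and a step that the two limits leave unreadable from compound 2 to compound 3, cannot be read in size or direction, since both ends of each sit at the limit; this is summed up by the limit of > 100000 nM in this assay, at which 3 of the 3 values shown sit.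

Compound 4, `COc1ccc(-c2cnc(NC(=O)c3ccc(Br)cc3)n2C)cc1`, differs from compound 3 by 4-bromophenyl in place of propyl on a carbonyl carbon.

Among the measured compounds shown here, no measured step can guide this change, so no step beyond the scatter is expected in this assay; the step from compound 3 to compound 4 is estimated as a step that the limit leaves unreadable from compound 3 to compound 4. Compound 4 is expected to give about 150000 nM, within 40000 nM to 600000 nM, most likely reported again as a limit.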

Compound 4, half-maximal cytotoxic concentration: > 100000 nM
Compound 4: no number, only a limit; the forecaster's own chance of this, stated with the estimate: 85%; the middle value does not contradict the limit.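

In this assay compound 4 gives > 100000 nM, a limit of the test and not a number. The steps to compound 4 from compound 1, compound 2 and compound 3 cannot be read in size or direction: the limit of > 100000 nM in this assay, at which 4 of the 4 values shown sit.

The compounds shown leave open whether swapping any of these groups changes the result in this assay at all.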